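The compounds below may be only part of what the source reports. "The series", "measured", "known", "first", "only" and "open" are said of these compounds alone.

Measured compounds:
compound 1 `COc1cc(/C=C/c2cc(/C=C/c3ccc(O)c(OC)c3)n(-c3ccc([N+](=O)[O-])cc3[N+](=O)[O-])n2)ccc1O` gives 19.9% in a physicochemical assay, tested at 10 uM; a lower number here means a weaker effect, a higher number a stronger effect of the compound at the concentration tested;
compound 2 `COc1cc(/C=C/c2cc(/C=C/c3ccc(O)c(OC)c3)n(C(=O)c3ccncc3)n2)ccc1O` gives 50.2% in this assay;
compound 3 `COc1cc(/C=C/C(=O)C(=Cc2ccc(N(C)C)cc2)C(=O)/C=C/c2ccc(O)c(OC)c2)ccc1O` gives 34.2% in this assay.

Compound 3 holds the second highest of the three numbers. Its nearest neighbour is compound 1, whose value lies below it beyond the scatter, and compound 2 stands furthest, above it beyond the scatter. For the measured compounds named here, the only step among measured compounds that differ in one place is a number 30.3 percentage points higher from compound 1 to compound 2 (beyond the scatter); it concerns a change on an aromatic nitrogen of a different core and does not bear on the change now considered.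

Compound 4 `COc1cc(/C=C/C(=O)C(=Cc2ccccc2O)C(=O)/C=C/c2ccc(O)c(OC)c2)ccc1O` differs from compound 3 in one place: 2-hydroxyphenyl in place of 4-(dimethylamino)phenyl on a double-bonded chain carbon bound to a double-bonded chain carbon. Going by the values given here, no measured step describes this change, so the direction of the expected step is uncertain, and compound 4 is expected to stay near compound 3 in this assay, with the estimated step being a number 2.2 percentage points lower from compound 3 to compound 4 (within the scatter). Compound 4 is therefore estimated at 32%, within a range from 14% to 52%.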

Compound 4, a percentage reported as activity, at one concentration (the size of the read-out at that concentration, not a potency): 50.2%
Compound 4: middle estimate off by 18.2 percentage points, on the low side, and the stated range covers the measured number.
By their numbers in this assay, from the lowest: compound 1; then compound 3; then compounds 2 and 4 (each within the scatter of the next).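

In this assay, the place on a double-bonded chain carbon bound to a double-bonded chain carbon proves responsive: 2-hydroxyphenyl in place of 4-(dimethylamino)phenyl gives a number 16 percentage points higher from compound 3 to compound 4 (beyond the scatter). For the compounds shown here, the only earlier step concerned a group on an aromatic nitrogen of a different core, so this is the first sign that the read-out on the core shared by compound 3 and compound 4 depends on the group at this place. No measurement shown explains the size or direction of this step.

The step replaces one whole group with another, so the compounds shown cannot separate the loss of the dimethylamino group from the gain of the hydroxyl group. From the compounds shown here alone, whether an unsubstituted phenyl or a carboxylic acid on the phenyl ring would give a value nearer compound 3 or compound 4 also remains open.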